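The source may report more compounds than this note shows. Statements on the series, on what has been measured and on what is new or still open speak of the compounds shown alone.

Compound 3 `COc1ccc(/C=C2\CCC/C(=C\c3cccc(Cl)c3)C2=O)cc1OC` gives 5100 nM in a functional assay on SW-620 cells (Homo sapiens) for cytotoxicity, read by MTT assay, with a stated time of 72 h (a lower number here means a stronger inhibitor, a higher number a weaker inhibitor), the lower of the two numbers shown; compound 1 `COc1cccc(/C=C2\CCC/C(=C\c3cccc(O)c3)C2=O)c1OC` sits within the scatter of it at 6400 nM. Compound 2 `COc1cccc(/C=C2\CCC/C(=C\c3ccc(O)cc3)C2=O)c1OC` reaches only the limit > 20000 nM in this assay. Among the compounds with values here, the one measured step, an at least 3.1-fold higher number from compound 1 to compound 2 (0.49 log units; beyond the scatter), concerns the hydroxyphenyl and rests on a limit (the limit of > 20000 nM in this assay, at which 1 of the 3 values shown sits); it carries no information about chloro. Compound 4 `COc1ccc(/C=C2\CCC/C(=C\c3cc(Cl)cc(Cl)c3)C2=O)cc1OC` differs from compound 3 by chloro in place of hydrogen on an aromatic carbon, 3-chlorophenyl to 3,5-dichlorophenyl. Within the data shown here, no measured step bears on a second chloro, so no step beyond the scatter is expected in this assay from compound 3 to compound 4. Compound 4 is therefore estimated at 4000 nM, with a range of 1500 nM to 12000 nM, an expected step of a 1.3-fold lower number from compound 3 to compound 4 (0.11 log units; within the scatter).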

Compound 4, half-maximal inhibitory concentration: 2500 nM
Beside the measured number, compound 4's estimate is 1.6-fold (0.20 log units) above it; measured number inside the range.
By their numbers in this assay, from the lowest: compound 4; then compounds 3 and 1 (each within the scatter of the next). At a limit, above all of these: compound 2.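

In this assay, within the data shown here, the change from 3-chlorophenyl to 3,5-dichlorophenyl gives a 2.0-fold lower number from compound 3 to compound 4 (0.31 log units; beyond the scatter), the first measured step at this aromatic carbon. A second chloro is therefore tolerated here and moves the number in the stronger direction, though the step is modest and rests on this single pair. Nothing at hand bears on the cause of this step.

From the compounds shown here alone, whether an amine, a nitrile or a carboxylic acid at this aromatic carbon would do the same remains open. Also open, going by these compounds, is whether a second chloro would give a similar step on the core of compound 1.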